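The compounds below may be only part of what the source reports. "The series", "measured", "known", "first", "only" and "open" are said of these compounds alone.

Measured compounds:
compound 1 `COC(=O)C[C@H](NC(=O)OC(C)(C)C)C(=O)N(Cc1ccccc1)C1(C(=O)NCc2ccccc2)CCN(Cc2ccccc2)CC1` — > 100000 nM
compound 2 `COC(=O)C[C@H](NC(=O)OC(C)(C)C)C(=O)N(Cc1ccc(F)cc1)C1(C(=O)NCc2ccccc2)CCNCC1` — 100000 nM
compound 3 `COC(=O)C[C@H](NC(=O)OC(C)(C)C)C(=O)N(Cc1ccc(F)cc1)C1(C(=O)NCc2ccccc2)CCN(C)CC1` — 17000 nM

In an ADME assay on MDCK cells (Canis lupus familiaris) for cytotoxicity, read by microscopy, with a stated time of 72 h (a higher number here means that more compound is tolerated, a lower number that less compound is tolerated), compound 3 holds the lowest of the two numbers shown; the result for compound 1 is a limit of this assay and not a number, the limit described by the limit of > 100000 nM in this assay, at which 1 of the 3 values shown sits. Within the data shown here, the only measured step that touches the ring amine nitrogen is a 5.9-fold lower number from compound 2 to compound 3 (0.77 log units; beyond the scatter).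

Compound 4 `COC(=O)C[C@H](NC(=O)OC(C)(C)C)C(=O)N(Cc1ccc(F)cc1)C1(C(=O)NCc2ccccc2)CCN(Cc2cccc(F)c2)CC1` is not yet measured in this assay. It differs from compound 3 by 3-fluorophenyl in place of hydrogen on a saturated chain carbon bound to an amine nitrogen in a ring. Compound 1, which carries a benzyl group on the same ring amine nitrogen among other differences, sat at the limit, whereas the methyl step lowered the number. Among the measured compounds shown here, with one step in each sense and no measured step for this exact change, a modest rise from compound 3 is expected rather than a further fall: the step from compound 3 to compound 4 is estimated at a 2.4-fold higher number from compound 3 to compound 4 (0.37 log units; beyond the scatter). Compound 4 is therefore expected to give about 40000 nM in this assay, within 12000 nM to 100000 nM.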

Compound 4, minimum cytotoxic concentration: 84000 nM
Compound 4: the middle estimate sits 2.1-fold (0.32 log units) below what was measured; measured number inside the range.
By their numbers in this assay, from the lowest: compound 3; then compounds 4 and 2 (each within the scatter of the next).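

In this assay, the ring amine nitrogen now has a second measured change, and it runs the opposite way to methyl: 3-fluorobenzyl in place of methyl gives a 4.9-fold higher number from compound 3 to compound 4 (0.69 log units; beyond the scatter). Against the free amine, the same group gives a 1.2-fold lower number from compound 2 to compound 4 (0.08 log units; within the scatter), so among hydrogen, methyl and 3-fluorobenzyl on this nitrogen, only methyl stands apart, with a lower number. The result for compound 1 is a limit and not a number, and that compound differs in more than one place, so it adds no step here: the limit of > 100000 nM in this assay, at which 1 of the 4 values shown sits.

Going by these compounds, whether the lower number belongs to methyl alone or extends to other small groups remains open; ethyl or acetyl on this nitrogen would test this. On these data alone, the part played by the fluorine also remains open, and a plain benzyl group on this nitrogen, with the rest of compound 4 unchanged, would address it.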